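A Fluoro Change on Compound 1, Still Unmeasured

The compounds below may be only part of what the source reports. "The series", "measured", "known", "first", "only" and "open" are said of these compounds alone.

Three measured compounds share one core and differ in the group on the amide carbonyl carbon. In a functional assay on A549 cells (Homo sapiens) for inhibition, read by MTT assay, with a stated time of 72 h (on this read-out higher numbers stand for weaker inhibition and lower numbers for stronger inhibition), compound 1 `C=C(Cl)C(=O)Nc1cc(Nc2nc3c(c(-c4cn(C)c5ccccc45)n2)CS(=O)(=O)CC3)c(OC)cc1N(C)CCN(C)C` gives 881 nM, the middle of the three numbers. Compound 2 `C/C=C\C(=O)Nc1cc(Nc2nc3c(c(-c4cn(C)c5ccccc45)n2)CS(=O)(=O)CC3)c(OC)cc1N(C)CCN(C)C` gives 4260 nM, and compound 3 `CCC/C=C\C(=O)Nc1cc(Nc2nc3c(c(-c4cn(C)c5ccccc45)n2)CS(=O)(=O)CC3)c(OC)cc1N(C)CCN(C)C` gives 57 nM.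

Compound 4 `C=C(Cl)C(=O)Nc1cc(Nc2nc3c(c(-c4cn(C)c5ccc(F)cc45)n2)CS(=O)(=O)CC3)c(OC)cc1N(C)CCN(C)C` keeps the 1-chloroethenyl group of compound 1 and differs elsewhere: fluoro in place of hydrogen on an aromatic carbon. In words, this is fluoro in place of hydrogen on an aromatic carbon, turning 1-methyl-1H-indol-3-yl into 5-fluoro-1-methyl-1H-indol-3-yl.

The measured steps bear on this change only indirectly. The step of a 4.8-fold higher number from compound 1 to compound 2 (0.68 log units; beyond the scatter) is modest, while a 15-fold lower number from compound 1 to compound 3 (1.19 log units; beyond the scatter) and a 75-fold lower number from compound 2 to compound 3 (1.87 log units; beyond the scatter) are large. All three show how far the numbers can move in this series, but all of them change the group on the carbonyl carbon, and none tests a fluoro. The data therefore give no direction for the new change, and no step beyond the scatter is expected in this assay. The expected outcome is a 1.1-fold lower number from compound 1 to compound 4 (0.04 log units; within the scatter). Compound 4 is estimated at 800 nM, with an expected range of 300 nM to 2100 nM.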

Compound 4, half-maximal inhibitory concentration: 3180 nM
Beside the measured number, compound 4's estimate is 4.0-fold (0.60 log units) below it, and the stated range ends below it.
By their numbers in this assay, from the lowest: compound 3; then compound 1; then compounds 4 and 2 (each within the scatter of the next).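

In this assay the change to 5-fluoro-1-methyl-1H-indol-3-yl gives a 3.6-fold higher number from compound 1 to compound 4 (0.56 log units; beyond the scatter) and so moves the read-out towards weaker inhibition. Among these compounds, every earlier step changed the group on the carbonyl carbon, so this is the first sign that the number also responds to a change elsewhere in the molecule, here the swap of a single hydrogen for fluoro on an aromatic carbon. Both this step and a 4.8-fold higher number from compound 1 to compound 2 (0.68 log units; beyond the scatter) are rated modest. Nothing shown here explains the new step.

Fluoro is the only group shown on this aromatic carbon, so it remains open whether a chloro, a methoxy or an amino group there would shift the number in the same direction. As far as these compounds go, it is also open whether the same fluoro would have a similar effect with the pent-1-en-1-yl group of compound 3 or the prop-1-en-1-yl group of compound 2 on the carbonyl carbon.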